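Adding One Methyl to Compound 2

This account rests on a few compounds, and the source may have more. Where it says the series, first, only, none or still open, it means among the compounds named here.

In an ADME assay on Caco-2 cells (Homo sapiens) for permeability, read by LC-MS, in the apical to basolateral direction, with a stated time of 2 h (a higher number here means that the compound crosses the layer faster, a lower number that the compound crosses the layer more slowly), compound 1 `COc1cc(C(=O)N2CCCC2(C)C)cc2nc(NCc3cccc(Cl)c3)oc12` stands as "not determined" (no result reported) and so offers no number. Compound 2 `COc1cc(C(=O)N2CCC(O)CC2)cc2nc(NCc3cccc(Cl)c3)oc12` at 71 nm/s holds the only number shown and can be ranked against nothing. Within the data shown here, compound 3 `COc1cc(C(=O)N2CCC(O)C(C)C2)cc2nc(NCc3cccc(Cl)c3)oc12` carries methyl in place of hydrogen on a saturated ring carbon, a difference counted as methyl in place of hydrogen on a saturated ring carbon with no measured pair to gauge it by. The expected step of a 1.1-fold higher number from compound 2 to compound 3 (0.05 log units; within the scatter) is small and upward, not beyond the scatter of this assay in this reading. For compound 3 the estimated value is 80 nm/s with an expected range of 38 nm/s to 165 nm/s in this measurement.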

Compound 3, apparent permeability: 84 nm/s
Compound 3: middle estimate off by 1.1-fold (0.02 log units), on the low side; the range from low to high includes it.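

In this assay, methyl in place of hydrogen on a saturated ring carbon, next to the ring atom that bears a hydroxy group, gives a 1.2-fold higher number from compound 2 to compound 3 (0.07 log units; within the scatter), so compound 2 and compound 3 cannot be told apart in this reading. Among these compounds, this is the first measured pair, and it shows that this position can carry a methyl with no step beyond the scatter. No information at hand gives a reason for this result. The compounds shown leave open whether an ethyl or a methoxy group at this ring carbon would stay within the scatter. They also leave open what an amine in place of the hydroxy group would give.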